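The source may hold more compounds than are shown below. What is called first, only, known or untested is meant among the compounds shown, and "the series" means these compounds.

In a physicochemical assay for lipophilicity, measured as octanol-water partition (on this read-out lower numbers stand for lower lipophilicity and higher numbers for higher lipophilicity), compound 2 `Cc1c(NCc2nnc(-c3ccc(N)cc3)o2)c(=O)n(-c2ccccc2)n1C` stands lowest of the two measured compounds at 1.13, while compound 1 `Cc1cccc(-c2nnc(CNc3c(C)n(C)n(-c4ccccc4)c3=O)o2)c1` gives 2.39. Compound 3 `Cc1c(NCc2nnc(-c3ccc(Cl)cc3)o2)c(=O)n(-c2ccccc2)n1C` remains unmeasured and differs from compound 2 by one change: chloro in place of amino on an aromatic carbon. Going by the values given here, the only measured step bearing on this is the large a number 1.26 log units lower from compound 1 to compound 2 (beyond the scatter), which introduced the 4-aminophenyl group now leaving. A similarly large rise in this assay is therefore expected, with an estimated a number 1.47 log units higher from compound 2 to compound 3 (beyond the scatter). Compound 3 is expected at 2.6, with an estimated range of 2.2 to 3.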

Compound 3, partition coefficient: 2.7
Compound 3: middle estimate off by 0.10 log units, on the low side, within the range that was stated.
By their numbers in this assay, from the lowest: compound 2; then compound 1; then compound 3.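

In this assay, chloro in place of amino gives a number 1.57 log units higher from compound 2 to compound 3 (beyond the scatter) and reverses almost all of the fall that came with the 4-aminophenyl group. 4-Chlorophenyl in place of 3-methylphenyl gives only a number 0.31 log units higher from compound 1 to compound 3 (beyond the scatter) as its step, so compound 1 and compound 3 lie far closer to each other than either does to compound 2. Among these three compounds, the low number therefore goes with the amino compound alone.

Open, on these data alone, is where a carboxylic acid or a dimethylamino group on this phenyl ring would fall, and how much of the step between 3-methylphenyl and 4-chlorophenyl follows the group and how much its place. Nothing available accounts for the size of these steps.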